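The source may report more compounds than this note shows. Statements on the series, on what has been measured and on what is new or still open speak of the compounds shown alone.

For the measured compounds named here, in a functional assay on MCF7 cells (Homo sapiens) for inhibition, read by CCK-8 assay, with a stated time of 48 h (a lower number here means a stronger inhibitor, a higher number a weaker inhibitor), compound 2, `COc1ccc(-c2cc3nccc(-c4cc(OC)c(OC)c(OC)c4)n3n2)cc1F`, gives 183 nM, and it is the one compound among those measured for which a number rather than a limit is reported. Compound 1, `COc1cc(-c2ccnc3c(-c4ccc(C)cc4)cnn23)cc(OC)c1OC`, sits at the limit of the assay with > 10000 nM. Compound 3, `Cc1ccc(-c2cc3nccc(-c4ccc(F)cc4)n3n2)cc1`, likewise sits at the limit with > 10000 nM. Going by the values given here, the limit of the limit of > 10000 nM in this assay, at which 2 of the 3 values shown sit, therefore frames the whole set, and no step between two measured compounds that differ in a single place is available.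

Compound 4, `COc1cc(-c2ccnc3cc(-c4ccc(C(F)(F)F)cc4)nn23)cc(OC)c1OC`, is not yet measured. It differs from compound 2 by 4-(trifluoromethyl)phenyl in place of 3-fluoro-4-methoxyphenyl on an aromatic carbon. The hydrogen-bond acceptor of the methoxy group on the leaving ring is lost, and no acceptor is counted on the entering 4-(trifluoromethyl)phenyl. Among the compounds with values here, with no measured step to lean on, compound 4 is expected to be weaker than compound 2 in this assay, by a step of an 8.2-fold higher number from compound 2 to compound 4 (0.91 log units; beyond the scatter), which is beyond the usual scatter. Compound 4 is accordingly estimated at 1500 nM, within a range from 300 nM to 10000 nM.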

Compound 4, half-maximal inhibitory concentration: 2440 nM
Estimate against measurement, compound 4: 1.6-fold (0.21 log units) below; measured number inside the range.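

In this assay, for the compounds shown here, this is the first single change that can be read in the set: on an aromatic carbon of the five-membered aromatic ring, 4-(trifluoromethyl)phenyl in place of 3-fluoro-4-methoxyphenyl gives a 13-fold higher number from compound 2 to compound 4 (1.12 log units; beyond the scatter). The position is therefore sensitive to which aryl group it carries, and the hydrogen-bond acceptor counted on the leaving group is absent from the entering one. Even so, compound 4 gives 2440 nM. Compound 1 and compound 3 remain at a limit of the assay: the limit of > 10000 nM in this assay, at which 2 of the 4 values shown sit.

The methoxy, the fluorine and the trifluoromethyl all change in this one step, and the compounds shown leave open which of them accounts for it. Also open, going by these compounds, is how an unsubstituted phenyl, an amine or a carboxylic acid would read at this carbon.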